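Allyl for Ethyl: an Expected Gain in Paw Edema Inhibition

This account rests on a few compounds, and the source may have more. Where it says the series, first, only, none or still open, it means among the compounds named here.

Compound 2 `CCn1c(SCC(=O)c2ccccc2)nnc1-c1ccccc1` and compound 1 `C=CCn1c(SCC(=O)c2ccccc2)nnc1-c1ccccc1` share one core and differ in a single place. In a functional assay on the whole organism (strain albino) for inhibition, with Rattus norvegicus as the target, read by paw edema, with a stated time of 5 h, at a dose of 0.28 mmol/kg by the oral route (a higher number here means more inhibition at the dose given (going by the name of the read-out), a lower number less inhibition), compound 2 gives 51%, while compound 1 gives 66%. The change between them, (vinyl in place of methyl on a saturated chain carbon bound to an aromatic nitrogen), made a step of a number 15 percentage points higher from compound 2 to compound 1 (beyond the scatter).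

Compound 3 `CCn1c(SC/C(=N/O)c2ccccc2)nnc1-c1cc(OC)c(OC)c(OC)c1` carries a different core; how its core differs from the core of compound 2 is not broken down here. In this assay compound 3 gives 74%, the highest of the three numbers, within the scatter of compound 1 and beyond the scatter of compound 2.

Compound 4 `C=CCn1c(SC/C(=N/O)c2ccccc2)nnc1-c1cc(OC)c(OC)c(OC)c1` has not yet been measured. It differs from compound 3 by vinyl in place of methyl on a saturated chain carbon bound to an aromatic nitrogen, the same change that separates compound 2 from compound 1, at the same place. Because that change earlier gave a number 15 percentage points higher from compound 2 to compound 1 (beyond the scatter), compound 4 is expected to show a step of a number 11 percentage points higher from compound 3 to compound 4 (beyond the scatter), taken a little smaller than the earlier one, as compound 3 already sits high on a percentage scale. Compound 4 is therefore estimated at 85%, with a likely range from 72% to 95%.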

Compound 4, a percentage reported as inhibition, in the whole organism at one dose (the size of the read-out at that dose, not a potency): 77%
Estimate against measurement, compound 4: 8 percentage points above; low and high end bracket the measured number.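

On the second core, the change of ethyl to allyl gave a number 3 percentage points higher from compound 3 to compound 4 (within the scatter) in this assay, so here the step does not stand clear of the scatter as it did on the first core. Set side by side, the two steps cannot be told apart: the same change on two cores in this assay, a number 15 percentage points higher (beyond the scatter) from compound 2 to compound 1 and a number 3 percentage points higher (within the scatter) from compound 3 to compound 4, 12 percentage points apart, within the scatter of two such steps. The two pairs therefore fit a single step shared by both cores, but they fit a step that is smaller on the second core equally well, and they neither prove nor rule out that the change carries over unchanged from one core to another.

Within the data shown here, with only two pairs, each read at one dose and one time, it stays open which features of the two cores, if any, bear on the size of the step. From the compounds shown here alone, it is also open how this series would respond at the same place to a longer chain such as butyl, to a benzyl group, or to a chain ending in a carboxylic acid.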